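The source may hold more compounds than are shown below. What is called first, only, known or untested is meant among the compounds shown, and "the series" means these compounds.

Within the data shown here, in an ADME assay on HEK-293T cells (Homo sapiens) for inhibition, read by CCK-8 assay, with a stated time of 48 h, tested at 20 uM (a lower number here means less inhibition of growth, a higher number more inhibition of growth at the concentration tested), compound 1 (`COc1ccc(Cc2nnc(NC(=O)/C(C#N)=C/c3ccccc3OS(=O)(=O)c3ccc(OC)cc3)s2)cc1`) gives 30%, the higher of the two numbers known so far. Compound 2 (`COc1ccc(Cc2nnc(NC(=O)/C(C#N)=C/c3ccccc3OS(=O)(=O)c3ccccc3[N+](=O)[O-])s2)cc1`) gives 18%. This modest step, a number 12 percentage points lower from compound 1 to compound 2 (beyond the scatter), puts 2-nitrophenyl in place of 4-methoxyphenyl on a sulfonyl sulfur. Compound 3 (`COc1ccc(S(=O)(=O)Oc2ccccc2/C=C(\C#N)C(=O)Nc2nnc(Cc3ccc(C)cc3)s2)cc1`) keeps the 4-methoxyphenyl there and differs elsewhere, with 4-methylbenzyl in place of 4-methoxybenzyl: methyl in place of methoxy on an aromatic carbon. Among the measured compounds shown here, no measured step touches this place, so the evidence is thin, and no change beyond the scatter is expected. The expected step is a number 3 percentage points lower from compound 1 to compound 3 (within the scatter). For compound 3 the estimate is 27%, with an expected range of 14% to 41%.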

Compound 3, percent growth inhibition at one concentration: 28%
Compound 3: the middle estimate sits 1 percentage points below what was measured, and the stated range covers the measured number.
By their numbers in this assay, from the lowest: compounds 2, 3 and 1 (each within the scatter of the next, the first and the last beyond it).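

Among these compounds, with 4-methylbenzyl in place of 4-methoxybenzyl, this assay shows a number 2 percentage points lower from compound 1 to compound 3 (within the scatter) and gives a first reading at this end of the molecule. On this aromatic carbon, a methyl can replace the methoxy, with one heavy atom and one hydrogen-bond acceptor fewer, and growth inhibition stays within the scatter. Nothing available explains this result. As far as these compounds go, what an amine, a carboxylic acid or a longer chain would do in this place remains open. So does whether this match would hold with 2-nitrophenyl on the sulfonyl sulfur.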